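The source may hold more compounds than are shown below. What is called first, only, known or untested is meant among the compounds shown, and "the series" means these compounds.

Of the compounds shown here, two sharing one core have been measured in an ADME assay on WI-38 cells (Homo sapiens) for cytotoxicity, read by MTT assay, with a stated time of 72 h; on this read-out lower numbers stand for stronger inhibition and higher numbers for weaker inhibition. Compound 1 is `O=C(O)CCc1cccc2c1B(O)OC2`. In this assay compound 1 gives > 100000 nM, which is a limit of the assay rather than a number. Compound 2 is `O=C(CCc1cccc2c1B(O)OC2)Nc1ccc(F)cc1`. In this assay compound 2 gives 12000 nM. Among the values shown, compound 2 provides the only actual number. The other value sits at the limit of > 100000 nM in this assay, at which 1 of the 2 values shown sits. For the measured compounds named here, no pair of measured compounds differs in a single place, so no measured step is available to guide the next change.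

Compound 3 is `COc1ccc(NC(=O)CCc2cccc3c2B(O)OC3)cc1`. It differs from compound 2 in one place: methoxy in place of fluoro on an aromatic carbon. Going by the values given here, with no measured step to rest on, the expected step is a 1.3-fold higher number from compound 2 to compound 3 (0.10 log units; within the scatter), a change that is not expected to exceed the usual scatter in either direction. Compound 3 is therefore expected to give about 15000 nM in this assay, within a range from 5000 nM to 50000 nM.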

Compound 3, half-maximal inhibitory concentration: > 100000 nM
Compound 3: no number, only a limit; the forecaster's own chance of this, stated with the estimate: 10%; middle value at least 6.6-fold (0.82 log units) from the limit.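

In this assay, exchanging fluoro for methoxy on an aromatic carbon para to a large group gives an at least 8.3-fold higher number from compound 2 to compound 3 (0.92 log units; beyond the scatter). For the compounds shown here, this is the first single-place comparison, and it shows that cell toxicity in this assay is sensitive to which group occupies this position, even though the change adds only a small number of heavy atoms. The true size of the step cannot be read, only its minimum, since compound 3 joins compound 1 at the top of the measurable range and compound 2 remains the only compound with an actual number: the limit of > 100000 nM in this assay, at which 2 of the 3 values shown sit.

Two groups at one position cannot show whether fluoro is the unusual group that permits toxicity or methoxy the unusual group that removes it, and a plain hydrogen, a chlorine atom, a methyl or an amine on the same carbon would help to separate these two readings. Going by these compounds, it also remains open whether methoxy would have the same effect on another carbon of that ring, or whether a longer chain in place of the methoxy would behave alike.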